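The source may report more compounds than this note shows. Statements on the series, on what has been measured and on what is new or still open speak of the compounds shown alone.

Four compounds share one core, and they differ in a side chain on an aromatic ring and in where that ring is joined. Compound 1 `CN(C)CCN(CCN(C)C)c1ccc(C(=O)N2CCc3ccc(OS(N)(=O)=O)cc3C2)cc1` carries a bis(2-(dimethylamino)ethyl)amino group, and in an assay on HEK293 cells for inhibition of Steryl-sulfatase (Homo sapiens), tested at 1 uM (on this read-out lower numbers stand for a weaker effect and higher numbers for a stronger effect at the one concentration tested), compound 1 gives 15.9%. Compound 2 `CC(C)CCN(CCC(C)C)c1ccc(C(=O)N2CCc3ccc(OS(N)(=O)=O)cc3C2)cc1` carries a diisopentylamino group instead; in this assay compound 2 gives 90.8%. The change diisopentylamino in place of bis(2-(dimethylamino)ethyl)amino on an aromatic carbon made the step of a number 74.9 percentage points higher from compound 1 to compound 2 (beyond the scatter).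

Compound 3 `CN(C)CCN(CCN(C)C)c1cccc(C(=O)N2CCc3ccc(OS(N)(=O)=O)cc3C2)c1` is built from the same atoms as compound 1, joined differently; the difference between the two cores is not broken down here. In this assay, within the data shown here, compound 3 gives 17.1%, and that number and the one for compound 1 lie within the usual scatter of each other.

Compound 4 `CC(C)CCN(CCC(C)C)c1cccc(C(=O)N2CCc3ccc(OS(N)(=O)=O)cc3C2)c1` is not yet measured. It differs from compound 3 by diisopentylamino in place of bis(2-(dimethylamino)ethyl)amino on an aromatic carbon. Among the measured compounds shown here, this is the same kind of change as the one from compound 1 to compound 2, but not the same change: there the group sits para to a large group, here meta to a large group. For the measured compounds named here, because the step of a number 74.9 percentage points higher from compound 1 to compound 2 (beyond the scatter) is large, a step of similar size is expected here, a number 67.9 percentage points higher from compound 3 to compound 4 (beyond the scatter), though only one earlier example supports it and the altered place adds uncertainty. Compound 4 is expected to give 85% in this assay, between 60% and 98%.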

Compound 4, a percentage reported as inhibition, at one concentration (the size of the read-out at that concentration, not a potency): 75.9%
Beside the measured number, compound 4's estimate is 9.1 percentage points above it; low and high end bracket the measured number.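

In this assay, putting diisopentylamino in place of bis(2-(dimethylamino)ethyl)amino again moves the number up on the second core, with a step of a number 58.8 percentage points higher from compound 3 to compound 4 (beyond the scatter) and a large size on both cores. The direction of the change carries over, but its size does not carry over exactly: the same change on two cores in this assay, a number 74.9 percentage points higher (beyond the scatter) from compound 1 to compound 2 and a number 58.8 percentage points higher (beyond the scatter) from compound 3 to compound 4, 16.1 percentage points apart, beyond the scatter of two such steps. This shows that, across these two pairs, the change can be moved from one core to the other and keep its direction; it does not show why the two steps differ in size, how the change would behave on any further core, or how strong the effect of any compound would be at another concentration, as each rests on a single pair and a single tested concentration.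

The compounds shown have either two diisopentylamino arms or two 2-(dimethylamino)ethyl arms on the nitrogen, so it remains open what a mixed amine with one isopentyl chain and one 2-(dimethylamino)ethyl chain would give. Also open, as far as these compounds go, is how shorter or longer chains, such as a dipropylamino or a dihexylamino group, or a carboxylic acid at the end of a chain, would read in this assay on either core.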